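A few compounds are considered here, and "the series" means these few. Any claim that something is new, unique, unknown or untested is made for them only; others in the source may bear on it.

Compound 1 `COc1cc(C(=O)/C=C/c2ccncc2)cc(OC)c1OC`: 7000 nM. Compound 2 `N#Cc1cccc(C(=O)/C=C/c2ccncc2)c1`: 85000 nM.

In a functional assay with Rattus norvegicus as the target (on this read-out lower numbers stand for stronger inhibition and higher numbers for weaker inhibition), compound 2 stands at the highest of the two numbers, the nearest being compound 1, whose value lies beyond the scatter below it. Compound 3 `O=C(/C=C/c1ccncc1)c1cccc(C(F)(F)F)c1` differs from compound 2 by trifluoromethyl in place of cyano on an aromatic carbon. Within the data shown here, no step between measured compounds tells how this change acts, so only a modest shift is expected, with no clear direction. For compound 3 the estimated step of a 1.7-fold lower number from compound 2 to compound 3 (0.23 log units; within the scatter) is expected to stay near the scatter. Compound 3 is thus expected to give 50000 nM, within 15000 nM to 200000 nM.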

Compound 3, half-maximal inhibitory concentration: 41000 nM
The estimate for compound 3 lay 1.2-fold (0.09 log units) above the measured number; the range from low to high includes it.
By their numbers in this assay, from the lowest: compound 1; then compound 3; then compound 2.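

In this assay, trifluoromethyl in place of cyano on an aromatic carbon, meta to a large group, gives a 2.1-fold lower number from compound 2 to compound 3 (0.32 log units; beyond the scatter) and so lies just beyond the scatter. Among these compounds, this gives the first reading of this change at this position: replacing the nitrile, which counts one hydrogen-bond acceptor, with trifluoromethyl, which counts none, moves the number only modestly. No measurement at hand accounts for this shift. On these data alone, whether an amine or a carboxylic acid at this position would move the number further, and in which direction, remains open.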